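Nitro in Place of Fluoro: What to Expect for Compound 4

The source may hold more compounds than are shown below. What is called first, only, known or untested is meant among the compounds shown, and "the series" means these compounds.

Two small hydrazines open the set: compound 1 `NNc1nc2ccc(F)cc2s1` gives 13.8 ug/mL in an ADME assay on MT4 cells (Homo sapiens) for cytotoxicity, read by MTT assay, with a stated time of 5 days (on this read-out higher numbers stand for lower toxicity in this test and lower numbers for higher toxicity in this test), and compound 2 `Cc1cccc2sc(NN)nc12` gives 9.8 ug/mL. Compound 3 `O=[N+]([O-])c1ccc(-c2nnc(-c3cccnc3)n2Nc2nc3ccc(F)cc3s2)cc1` stands apart: in this assay compound 3 reports only a limit of the assay, >= 108 ug/mL, so it sits at the limit of >= 108 ug/mL in this assay, at which 1 of the 3 values shown sits, rather than at a number. Compound 4 `O=[N+]([O-])c1ccc(-c2nnc(-c3cccnc3)n2Nc2nc3ccc([N+](=O)[O-])cc3s2)cc1` has not yet been measured; it differs from compound 3 by nitro in place of fluoro on an aromatic carbon. No step between two measured compounds is available, so the effect of this exchange cannot be read from the numbers shown. One expects the step of an at least 1.0-fold lower number from compound 3 to compound 4 (0.03 log units; that floor lies within the scatter) to be none beyond the scatter. Compound 4 is accordingly estimated at 100 ug/mL, within a range of 40 ug/mL to 200 ug/mL.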

Compound 4, half-maximal cytotoxic concentration: 50.8 ug/mL
Estimate against measurement, compound 4: 2.0-fold (0.29 log units) above; the measured number falls inside the stated range.
By their numbers in this assay, from the lowest: compounds 2 and 1 (each within the scatter of the next); then compound 4. At a limit, above all of these: compound 3.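

For the compounds shown here, this pair gives the first measured exchange at this aromatic carbon, and in this assay nitro in place of fluoro gives an at least 2.1-fold lower number from compound 3 to compound 4 (0.32 log units; beyond the scatter). On this read-out, compound 4 therefore shows higher toxicity in this test than compound 3. The true size of the step stays unknown beyond that floor, because compound 3 stands at a limit and not at a number: the limit of >= 108 ug/mL in this assay, at which 1 of the 4 values shown sits.

Going by these compounds alone, only this one pair carries the exchange, so whether it holds on another core remains open. Where an amine or a carboxylic acid at the same carbon would fall in this test also remains open.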